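The compounds below may be only part of what the source reports. "The series", "measured", "known", "first", "only" and "open" are said of these compounds alone.

Within the data shown here, compound 2 `N#Cc1ccc(-c2csc(N3N=C(c4ccc(N5CCCCC5)cc4)CC3c3ccc(Cl)cc3)n2)cc1` gives the lowest of the two numbers measured so far in a functional assay on A549 cells (Homo sapiens) for antiproliferative activity, read by MTT assay, with a stated time of 72 h (a higher number here means a weaker inhibitor, a lower number a stronger inhibitor), at 11200 nM. Among the measured compounds shown here, its nearest neighbour, compound 1 `Fc1ccc(-c2csc(N3N=C(c4ccc(N5CCCCC5)cc4)CC3c3ccc(Cl)cc3)n2)cc1`, gives 70200 nM in this assay, and the step of a 6.3-fold lower number from compound 1 to compound 2 (0.80 log units; beyond the scatter) is the only one recorded between measured compounds. Compound 3 `Cc1ccc(-c2csc(N3N=C(c4ccc(N5CCCCC5)cc4)CC3c3ccc(Cl)cc3)n2)cc1` has not yet been measured. It differs from compound 2 by methyl in place of cyano on an aromatic carbon, so that 4-cyanophenyl becomes 4-methylphenyl. Because the step of a 6.3-fold lower number from compound 1 to compound 2 (0.80 log units; beyond the scatter) accompanied the entry of the cyano group, its loss in compound 3 is expected to move the number back toward that of compound 1, although how closely methyl resembles fluoro on this shared core is not known from these two compounds alone. Compound 3 is therefore expected to show a 2.7-fold higher number from compound 2 to compound 3 (0.43 log units; beyond the scatter), giving an estimate of 30000 nM with a range from 8000 nM to 90000 nM.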

Compound 3, half-maximal inhibitory concentration: > 100000 nM
Compound 3: no number, only a limit; the forecaster's own chance of this, stated with the estimate: 10%; middle value at least 3.3-fold (0.52 log units) away from the limit.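

For compound 3 the result in this assay is a limit and not a number: the limit of > 100000 nM in this assay, at which 1 of the 3 values shown sits. Even so, the series now shows an at least 8.9-fold higher number from compound 2 to compound 3 (0.95 log units; beyond the scatter), so the lower number of compound 2 has been lost with two different replacements of the cyano group, fluoro and methyl, rather than with one. The comparison of the two compounds without the cyano group gives an at least 1.4-fold higher number from compound 1 to compound 3 (0.15 log units; that floor lies within the scatter), so methyl and fluoro cannot be put in order at this position.

As far as these compounds go, it remains open whether another group on this aromatic carbon, such as an amine, a carboxylic acid or a methoxy group, would keep or lose the number of compound 2. From the compounds shown here alone, the true number of compound 3 also stays unknown, as does whether the effect of the cyano group holds on any other core.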